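A Bromine Swap on a Weakly Active Compound

This account rests on a few compounds, and the source may have more. Where it says the series, first, only, none or still open, it means among the compounds named here.

So far three related compounds have been tested in a functional assay on SGC-7901 cells (Homo sapiens) for antiproliferative activity, read by sulforhodamine B assay, with a stated time of 72 h (a lower number here means a stronger inhibitor, a higher number a weaker inhibitor), and only one of them gives an actual number. Compound 2 `N#Cc1ccc(NC(=S)N/N=C/c2ccc3ccccc3n2)cc1` gives 23700 nM. Compound 1 `COc1ccc(C)cc1NC(=S)N/N=C/c1ccc2ccccc2n1` gives only a limit, > 100000 nM. Compound 3 `NC(=S)N/N=C/c1ccc2cccnc2n1` also gives only a limit, > 100000 nM. Compound 2 is therefore the sole firm reference point on the scale, and it is the natural place to start.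

The next compound to be tested is compound 4 `S=C(N/N=C/c1ccc2ccccc2n1)Nc1ccccc1Br`. It keeps the rest of compound 2 but carries 2-bromophenyl in place of 4-cyanophenyl on an amide-type nitrogen.

Going by the values given here, no pair of measured compounds shows what a single change of this kind does, so any forecast here is loose. It starts from compound 2 at 23700 nM. The other anchor in the data is the limit of > 100000 nM in this assay, at which 2 of the 3 values shown sit. That leaves more room for a loss of activity than for a gain, so a small move towards weaker inhibition is the likeliest outcome. The estimated change is a 1.5-fold higher number from compound 2 to compound 4 (0.17 log units; within the scatter), and it may not stand clear of the usual scatter. Compound 4 is expected to give 35000 nM, with an estimated range of 10000 nM to 100000 nM.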

Compound 4, half-maximal inhibitory concentration: > 100000 nM
Compound 4 gave a limit, no number; the forecaster's own chance of this, stated with the estimate: 35%; middle value at least 2.8-fold (0.45 log units) away from the limit.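

Going by these compounds alone, the change from 4-cyanophenyl to 2-bromophenyl on the amide-type nitrogen is the first single change here that can be read as a step, and it gives an at least 4.2-fold higher number from compound 2 to compound 4 (0.62 log units; beyond the scatter). This place on the compound therefore matters: the activity of compound 2 in this assay does not survive this swap of one substituted phenyl ring for another, even though the shared core stays the same. The step is a minimum rather than a full measure, and compound 2 remains the only compound with an actual number, since compound 4 has joined the others at the top of the scale: the limit of > 100000 nM in this assay, at which 3 of the 4 values shown sit.

The compounds shown do not separate the loss of the nitrile from the arrival of the bromine, since both happen in one swap and the substituent's place on the phenyl ring differs as well. From the compounds shown here alone, it also remains open whether a phenyl ring carrying an amine or a carboxylic acid on this nitrogen would bring the number below that of compound 2, or whether compound 2 is close to the best this place allows.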